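The source may hold more compounds than are shown below. What is called first, only, known or untested is meant among the compounds shown, and "the series" means these compounds.

Measured in an assay on aorta with Adrenergic receptor alpha-1 (Rattus norvegicus) as the target; on this read-out higher numbers stand for weaker binding and lower numbers for tighter binding: compound 1 `O=C(CNC1CCCCC1)NC(c1ccccc1)C1CCCCC1` gives 316 nM; compound 2 `CCN(CC)CC(=O)NC(c1ccccc1)C1CCCCC1` gives 1000 nM.

Compound 2 carries the highest of the two numbers, the nearest being compound 1. Compound 3 `O=C(CCNC1CCCCC1)NC(c1ccccc1)C1CCCCC1` is not yet measured in this assay. Its change from compound 2: (cyclohexylamino)methyl in place of diethylamino on a saturated chain carbon bound to a carbonyl carbon. Among the measured compounds shown here, the one measured step bearing on it is a 3.2-fold higher number from compound 1 to compound 2 (0.50 log units; beyond the scatter). Compound 3 reverses that replacement, restoring a cyclohexylamino as (cyclohexylamino)methyl, so a move back toward the value of compound 1 is expected, tempered by the changed chain. The step from compound 2 to compound 3 is expected to be a 2.5-fold lower number from compound 2 to compound 3 (0.40 log units; beyond the scatter). Compound 3 is estimated at 400 nM, range 130 nM to 1300 nM.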

Compound 3, dissociation constant: 794 nM
Estimate against measurement, compound 3: 2.0-fold (0.30 log units) below; the range from low to high includes it.
By their numbers in this assay, from the lowest: compound 1; then compounds 3 and 2 (each within the scatter of the next).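

In this assay, (cyclohexylamino)methyl on a saturated chain carbon bound to a carbonyl carbon does not keep the lower number seen with cyclohexylamino, giving a 2.5-fold higher number from compound 1 to compound 3 (0.40 log units; beyond the scatter). Set against diethylamino, the same group gives a 1.3-fold lower number from compound 2 to compound 3 (0.10 log units; within the scatter), so compound 2 and compound 3 stand level within the scatter, and only compound 1 separates from the others. No measured evidence accounts for this result.

Open, going by these compounds, is how a piperidine or morpholine at this place would compare with cyclohexylamino. Also open, on these data alone, is whether a longer chain carrying cyclohexylamino would stay level with compound 3.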